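The compounds below may be only part of what the source reports. "The series", "measured", "known", "first", "only" and "open" are said of these compounds alone.

Compound 3 `O=C(Nc1ccc(Cl)cc1)c1cccc(/C=C2\CC(=O)N(Cc3ccccc3)C2=O)c1` carries chloro on the aromatic carbon and benzyl on the amide-type nitrogen in the ring; in an ADME assay on HCT-116 cells (Homo sapiens) for cytotoxicity, read by MTT assay, with a stated time of 72 h (on this read-out higher numbers stand for weaker inhibition and lower numbers for stronger inhibition), compound 3 gives only a limit, > 100000 nM. Compound 1 `CCOc1ccc(NC(=O)c2cccc(/C=C3\CC(=O)N(Cc4ccccc4)C3=O)c2)cc1` differs from it by ethoxy in place of chloro on an aromatic carbon, and in this assay compound 1 gives 41700 nM, so the step is an at least 2.3-fold lower number from compound 3 to compound 1 (0.37 log units; beyond the scatter). Compound 2 `O=C(Nc1ccc(Cl)cc1)c1cccc(/C=C2\CC(=O)N(c3ccccc3)C2=O)c1` differs from compound 3 in the core by phenyl in place of benzyl on an amide-type nitrogen in a ring; in this assay compound 2 gives only a limit, > 100000 nM. The core step that the two limits leave unreadable from compound 2 to compound 3 cannot be sized, as both values sit at the limit of > 100000 nM in this assay, at which 2 of the 3 values shown sit. Compound 4 `CCOc1ccc(NC(=O)c2cccc(/C=C3\CC(=O)N(c4ccccc4)C3=O)c2)cc1` is not yet measured; it differs from compound 2 by ethoxy in place of chloro on an aromatic carbon, the same change as that from compound 3 to compound 1, with the place described in the same words. The expected step is an at least 1.4-fold lower number from compound 2 to compound 4 (0.15 log units; that floor lies within the scatter), resting on an at least 2.3-fold lower number from compound 3 to compound 1 (0.37 log units; beyond the scatter) and on compound 2 sitting at the limit of > 100000 nM in this assay, at which 2 of the 3 values shown sit. Compound 4 is therefore estimated near 70000 nM, within 25000 nM to 200000 nM.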

Compound 4, half-maximal inhibitory concentration: 84800 nM
Beside the measured number, compound 4's estimate is 1.2-fold (0.08 log units) below it, and the stated range covers the measured number.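

In this assay, ethoxy in place of chloro gives an at least 1.1-fold lower number from compound 2 to compound 4 (0.07 log units; that floor lies within the scatter), and the two cores can be set side by side only this far: the same change on two cores in this assay, an at least 2.3-fold lower number (0.37 log units; beyond the scatter) from compound 3 to compound 1 and an at least 1.1-fold lower number (0.07 log units; that floor lies within the scatter) from compound 2 to compound 4; the limit leaves it open whether they differ. Compound 2 gives only a limit, > 100000 nM. With ethoxy held, phenyl in place of benzyl gives a 2.0-fold higher number from compound 1 to compound 4 (0.31 log units; beyond the scatter), whereas the same core step between the chloro compounds cannot be read, so the data neither show that the ethoxy step carries over unchanged nor size it on either core.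

Open, on these data alone, is how an amine or a longer alkoxy chain in place of ethoxy would read on these two cores. Also open, as far as these compounds go, is whether a chloro compound on either core can be brought into the measurable range.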